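Amine substituent change in the shared core series

A few compounds are considered here, and "the series" means these few. Any claim that something is new, unique, unknown or untested is made for them only; others in the source may bear on it.

Compound 1 `CCCn1c(=O)[nH]c2nc(-c3ccc(S(=O)(=O)N4CCN(c5ccccc5C)CC4)cc3)[nH]c2c1=O` — an assay on CHO cells for displacement of a labelled ligand from adenosine receptor A3 (Homo sapiens), read by scintillation counting, with a stated time of 45 min, in the presence of a further agent that is not named here; a lower number here means a stronger inhibitor, a higher number a weaker inhibitor: > 1000 nM
Compound 2 `CCCn1c(=O)[nH]c2nc(-c3ccc(S(=O)(=O)N4CCN(c5cccc(Br)c5)CC4)cc3)[nH]c2c1=O` — this assay: > 1000 nM

In this assay compound 1 gives > 1000 nM, which is a limit of the assay and not a number. In this assay compound 2 gives > 1000 nM, likewise a limit. The step that the two limits leave unreadable from compound 1 to compound 2 therefore cannot be read, and the limit of > 1000 nM in this assay, at which 2 of the 2 values shown sit, is where both values sit; compound 2 stands only at that limit, and no order between compound 1 and compound 2 can be given.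

Compound 3 `CCCn1c(=O)[nH]c2nc(-c3ccc(S(=O)(=O)N4CCN(C(C)c5ccccc5)CC4)cc3)[nH]c2c1=O` is to be measured in this assay. Its change from compound 2 is 1-phenylethyl in place of 3-bromophenyl on an amine nitrogen in a ring. For the measured compounds named here, no measured step bears on this change, since the only measured step is a step that the two limits leave unreadable from compound 1 to compound 2, which is unreadable. Compound 3 is therefore expected to remain weak, with a step that the limit leaves unreadable from compound 2 to compound 3 not readable beyond the scatter. The estimate for compound 3 in this assay is 2000 nM, in a range from 400 nM to 10000 nM.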

Compound 3, inhibition constant: > 1000 nM
Compound 3 ended at the assay's limit; the forecaster's own chance of this, stated with the estimate: 70%; the middle value does not contradict the limit.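

In this assay compound 3 gives > 1000 nM, which is a limit of the assay and not a number. The steps to compound 3 from compound 1 and compound 2 therefore cannot be read: the limit of > 1000 nM in this assay, at which 3 of the 3 values shown sit.

The compounds shown leave open the actual strength of all three compounds and any order among them.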